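A few compounds are considered here, and "the series" means these few. Any claim that something is new, unique, unknown or untested is made for them only; others in the source may bear on it.

Compound 1 `CCOC(=O)/C=C/CO/N=C(/c1ccc(OC)c(OC)c1OC)c1cccc2ccccc12` gives 14000 nM in a functional assay on A549 cells (Homo sapiens) for inhibition, read by sulforhodamine B assay, with a stated time of 48 h; a lower number here means a stronger inhibitor, a higher number a weaker inhibitor.
Compound 2 `COc1ccc(/C(=C\c2ccc(F)cc2)c2cccc3ccccc23)c(OC)c1OC` reaches only a limit in this assay, > 20000 nM.
Compound 3 `COc1ccc(/C(=C/c2ccc(F)cc2)c2cccc3ccccc23)c(OC)c1OC` gives 18600 nM in this assay.

Of the two numbers shown, compound 3 has the highest, but its gap to compound 1 lies within the scatter, so the two cannot be told apart. Within the data shown here, the one measured step, an at least 1.0-fold lower number from compound 2 to compound 3 (0.03 log units; that floor lies within the scatter), changes only how the double bond is drawn, and its size is set by the limit of > 20000 nM in this assay, at which 1 of the 3 values shown sits, and the fact that compounds 2 and 3 differ only in the configuration as drawn rather than by a swap of groups.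

Compound 4 `COc1ccc(/C(=C/c2ccc(C)cc2)c2cccc3ccccc23)c(OC)c1OC` differs from compound 3 by methyl in place of fluoro on an aromatic carbon. Among the measured compounds shown here, no measured step swaps a group on that ring, so nothing here points to a direction; a step of a 1.2-fold lower number from compound 3 to compound 4 (0.07 log units; within the scatter) within the scatter is expected. Compound 4 is therefore estimated at 16000 nM, with a range from 5000 nM to 60000 nM.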

Compound 4, half-maximal inhibitory concentration: 19600 nM
Compound 4: middle estimate off by 1.2-fold (0.09 log units), on the low side, within the range that was stated.
By their numbers in this assay, from the lowest: compounds 1, 3 and 4 (each within the scatter of the next). At a limit, above all of these: compound 2.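

Among these compounds, replacing fluoro with methyl at this position gives a 1.1-fold higher number from compound 3 to compound 4 (0.02 log units; within the scatter), the first measured step on this ring, so this assay does not tell these two groups apart. Compound 4 therefore joins compounds 1 and 3 in a group whose numbers cannot be separated. Compound 2 cannot be placed within that order because its result is a limit, not a number: the limit of > 20000 nM in this assay, at which 1 of the 4 values shown sits.

From the compounds shown here alone, whether an amine or a carboxylic acid at this position would move the number beyond the scatter remains open. Also open, going by these compounds, is whether the same swap would read alike with the double bond drawn Z.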